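A few compounds are considered here, and "the series" means these few. Any claim that something is new, unique, unknown or untested is made for them only; others in the source may bear on it.

Measured so far in an ADME assay on HEp-2 cells (Homo sapiens) for cytotoxicity; on this read-out lower numbers stand for higher toxicity in this test and higher numbers for lower toxicity in this test:
compound 1 `CC(=O)NCc1ccc2c(c1)nc(Cn1c(=O)n(C(C)C)c3ccccc31)n2CCC(C)C`, 178000 nM
compound 2 `CC(C)CCn1c(Cn2c(=O)n(C(C)C)c3ccccc32)nc2ccc(CN)cc21`, 28100 nM
compound 3 `C=C(C)n1c(=O)n(Cc2nc3cc(C#N)ccc3n2CCC(C)C)c2ccccc21`, 1480 nM

Of the three, compound 1 stands highest in this assay, that is, it is the least toxic of the set; compound 2 gives a clearly lower number and compound 3 the lowest of all. Compound 4 `CC(C)CCn1c(Cn2c(=O)n(C(C)C)c3ccccc32)nc2cc(C(=O)N(C)C)ccc21` keeps the core of compound 1 and differs from it in one place: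

dimethylcarbamoyl in place of acetamidomethyl on an aromatic carbon

Within the data shown here, no measured pair shows the effect of such an exchange, so the step can only be estimated. The exchange keeps the count of heavy atoms and removes the single hydrogen-bond donor; compound 4 is expected to give a modestly lower number than compound 1, a 1.8-fold lower number from compound 1 to compound 4 (0.25 log units; within the scatter), at the edge of the scatter. The estimate for compound 4 is 100000 nM, within a range from 30000 nM to 250000 nM.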

Compound 4, half-maximal cytotoxic concentration: 25600 nM
Compound 4: middle estimate off by 3.9-fold (0.59 log units), on the high side; measured number outside the range, below it.
By their numbers in this assay, from the lowest: compound 3; then compounds 4 and 2 (each within the scatter of the next); then compound 1.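

In this assay, this place on the aromatic carbon responds to the exchange itself: with the heavy-atom count unchanged, dimethylcarbamoyl in place of acetamidomethyl gives a 7.0-fold lower number from compound 1 to compound 4 (0.84 log units; beyond the scatter). Among these compounds, this is the first single-place comparison in the set, and it shows that a group of the same size and atom makeup need not give the same number here. No measurement at hand gives a cause for this step. One pair cannot separate loss of the hydrogen-bond donor from the different joining of the atoms, and a methylcarbamoyl group or a carboxylic acid at this place remains untested among the compounds shown.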